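The source may hold more compounds than are shown below. What is called first, only, known or untested is meant among the compounds shown, and "the series" means these compounds.

Compound 1 `Cn1cncc1CN1CC(N(CC2CCN(C(=O)OC(C)(C)C)CC2)S(=O)(=O)c2ccccn2)Cc2cc(C#N)ccc21` belongs to a small set of three compounds that share a common core and differ only in the group carried on the sulfonamide nitrogen. In an ADME assay on Caco-2 cells (Homo sapiens) for permeability, in the apical to basolateral direction (a higher number here means that the compound crosses the layer faster, a lower number that the compound crosses the layer more slowly), compound 1 gives 15.5 10^-6 cm/s. Compound 2 `Cn1cncc1CN1CC(N(CCn2cccc2)S(=O)(=O)c2ccccn2)Cc2cc(C#N)ccc21` gives 12.4 10^-6 cm/s in this assay, and compound 3 `Cc1noc(C)c1CN(C1Cc2cc(C#N)ccc2N(Cc2cncn2C)C1)S(=O)(=O)c1ccccn1` gives 8 10^-6 cm/s. For the measured compounds named here, the only step between two measured compounds that differ in one place is a 1.6-fold lower number from compound 2 to compound 3 (0.19 log units; within the scatter), and the gaps from compound 1 to compound 2 and from compound 1 to compound 3 likewise fall within the scatter, so the three measured compounds cannot be told apart on this read-out.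

Compound 4 `Cn1cncc1CN1CC(N(CC2CCN(C(=O)N3CCCCC3)CC2)S(=O)(=O)c2ccccn2)Cc2cc(C#N)ccc21` is reached from compound 1 by the change (piperidin-1-yl in place of tert-butoxy on a carbonyl carbon). This change sits on the carbonyl carbon of the group attached to the sulfonamide side chain, a place that none of the measured steps touches: the one step shown, from compound 2 to compound 3, alters the group bound directly to the sulfonamide nitrogen and is within the scatter. Going by the values given here, no measured step therefore bears on the carbonyl substituent, and the account can only say that nothing so far has moved this read-out beyond the scatter.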

Compound 4, apparent permeability: 0.6 10^-6 cm/s
The estimate for compound 4 lay 20-fold (1.30 log units) above the measured number; measured number below the stated range.
By their numbers in this assay, from the lowest: compound 4; then compounds 3, 2 and 1 (each within the scatter of the next).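

In this assay, for the compounds shown here, piperidin-1-yl in place of tert-butoxy on a carbonyl carbon gives a 26-fold lower number from compound 1 to compound 4 (1.41 log units; beyond the scatter), the only step so far that lies beyond the scatter. The earlier compounds shown here differed from one another without leaving the scatter, whereas this result shows that the read-out can respond strongly to the group on this carbonyl carbon, even with the rest of compound 1 unchanged. The exchange alters the atom bound to the carbonyl carbon, from oxygen to nitrogen, and also brings in a six-membered non-aromatic ring, but nothing available explains the large step or links it to either difference.

The compounds shown do not separate these two differences, so it remains open whether an open-chain diethylamino group on the carbonyl carbon would track piperidin-1-yl, or whether a cyclohexyloxy group would track tert-butoxy. As far as these compounds go, it is also open whether the same exchange would produce a step of similar size with another group on the sulfonamide nitrogen or another group in place of the whole carbonyl unit, such as a simple acetyl group.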